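Swapping the double-bond geometry of compound 1

A few compounds are considered here, and "the series" means these few. Any claim that something is new, unique, unknown or untested is made for them only; others in the source may bear on it.

For the measured compounds named here, compound 1 `O=C(O)C(CCC/C=C(/c1cccnc1)c1cccs1)c1ccccc1` stands lowest of the two numbers so far: in an assay (Equus caballus) for inhibition of Thromboxane-A synthase (Homo sapiens), using microsomes (a higher number here means a weaker inhibitor, a lower number a stronger inhibitor), compound 1 gives 32 nM. Compound 2 `O=C(O)CCCC/C=C(/c1cccnc1)c1cccs1`, which has hydrogen in place of phenyl on the chain carbon next to the carbonyl, gives 54 nM; the step of a 1.7-fold higher number from compound 1 to compound 2 (0.23 log units; within the scatter) is within the scatter. Compound 3 `O=C(O)C(CCC/C=C(\c1cccnc1)c1cccs1)c1ccccc1` differs from compound 1 only in geometry: the two compounds have the same atoms and bonds; at least one stereo element is drawn with a configuration in one of them and without one in the other: 1 of 2 stereo elements differ; a double bond is drawn Z in compound 1 and E in compound 3. Going by the values given here, no measured step touches such a change, so no direction can be read from the data. Compound 3 is therefore expected near compound 1, with a broad range, at 60 nM (10 nM to 400 nM), a step of a 1.9-fold higher number from compound 1 to compound 3 (0.27 log units; within the scatter).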

Compound 3, half-maximal inhibitory concentration: 50 nM
Compound 3: middle estimate off by 1.2-fold (0.08 log units), on the high side; low and high end bracket the measured number.
By their numbers in this assay, from the lowest: compounds 1, 3 and 2 (each within the scatter of the next).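

The earlier step changed only the chain, whereas this pair changes the double bond itself. In this assay the Z and E forms give a 1.6-fold higher number from compound 1 to compound 3 (0.19 log units; within the scatter) and so cannot be told apart at this position. This reading carries one caution: the fact that one of compounds 1 and 3 is drawn with a defined configuration and the other without, at the place where they differ.

Still open, from the compounds shown here alone, is whether the double-bond geometry would matter without the phenyl group, as in compound 2. Also open, going by these compounds, is whether a longer chain, or an amide in place of the carboxylic acid, would shift the number beyond the scatter.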